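Notes on aryl substituent changes in one triazole series

The source may hold more compounds than are shown below. What is called first, only, known or untested is meant among the compounds shown, and "the series" means these compounds.

compound 1 `Cc1ccccc1-n1nncc1CN1C(=O)C2(C(C#N)=C(N)Oc3c2c2nc4ccccc4nc2c2ccccc32)c2ccccc21` in a functional assay on MCF7 cells (Homo sapiens) for antiproliferative activity, read by MTT assay, with a stated time of 48 h; on this read-out lower numbers stand for stronger inhibition and higher numbers for weaker inhibition: > 50000 nM
compound 2 `N#CC1=C(N)Oc2c(c3nc4ccccc4nc3c3ccccc23)C12C(=O)N(Cc1cnnn1-c1ccc(F)cc1)c1ccccc12` in this assay: > 50000 nM
compound 3 `N#CC1=C(N)Oc2c(c3nc4ccccc4nc3c3ccccc23)C12C(=O)N(Cc1cnnn1-c1ccc(Cl)cc1)c1ccccc12` in this assay: > 50000 nM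

Compound 1 gives only a limit, not a number, in this assay: > 50000 nM. Compound 2 likewise gives a limit, > 50000 nM. Compound 3 likewise gives a limit, > 50000 nM. All three sit at the limit of > 50000 nM in this assay, at which 3 of the 3 values shown sit. The steps a step that the two limits leave unreadable from compound 1 to compound 2, a step that the two limits leave unreadable from compound 1 to compound 3 and a step that the two limits leave unreadable from compound 2 to compound 3 are accordingly unreadable in size and direction. Compound 4 `N#CC1=C(N)Oc2c(c3nc4ccccc4nc3c3ccccc23)C12C(=O)N(Cc1cnnn1-c1ccccc1Cl)c1ccccc12` differs from compound 1 by chloro in place of methyl on an aromatic carbon. The three unreadable steps bear on it only in that no change on the phenyl so far has moved any value off the limit. Compound 4 is therefore expected to return a limit as well, which means an expected step that the limit leaves unreadable from compound 1 to compound 4. The estimate for compound 4 is 80000 nM, with an expected range from 30000 nM to 300000 nM.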

Compound 4, half-maximal inhibitory concentration: > 50000 nM
Compound 4: only a limit was reported (the forecaster's own chance of this, stated with the estimate: 85%); the middle value lies beyond the limit too.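

In this assay compound 4 gives > 50000 nM as a limit, not a number, so its steps from compound 1, compound 2 and compound 3 cannot be read. The compounds shown leave open whether any phenyl substituent brings a value off the limit: the limit of > 50000 nM in this assay, at which 4 of the 4 values shown sit.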